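The source may report more compounds than this note shows. Statements on the series, on what has been measured and on what is new or still open speak of the compounds shown alone.

Among the measured compounds shown here, compound 2, with structure `O=[N+]([O-])c1cn2c(n1)OC[C@@H](OCc1cc(-c3ccc(F)cc3)no1)C2`, is one of the two compounds so far measured in an ADME assay on Vero cells (Chlorocebus sabaeus) for cytotoxicity, with a stated time of 72 h; on this read-out lower numbers stand for stronger inhibition and higher numbers for weaker inhibition. In this assay compound 2 gives > 128000 nM, which is a limit of the assay rather than a number. Compound 1, with structure `N#Cc1ccc(-c2cc(CO[C@@H]3COc4nc([N+](=O)[O-])cn4C3)on2)cc1`, is the other measured compound. In this assay compound 1 gives > 128000 nM, again a limit. For the measured compounds named here, the single measured step, a step that the two limits leave unreadable from compound 1 to compound 2, therefore has no readable size. Compound 3, with structure `COc1ccc(-c2cc(CO[C@@H]3COc4nc([N+](=O)[O-])cn4C3)on2)cc1F`, has not yet been measured. It differs from compound 2 in one place: 3-fluoro-4-methoxyphenyl in place of 4-fluorophenyl on an aromatic carbon. Going by the values given here, the only measured step that bears on this change is the one from compound 1 to compound 2, and since its size cannot be read, it gives no guide to direction or magnitude. What the two values do show is simply (the limit of > 128000 nM in this assay, at which 2 of the 2 values shown sit). On that basis compound 3 is expected to sit at or near the same limit, and the step of a number no higher from compound 2 to compound 3 (the limit leaves the size open) is estimated to be none beyond the scatter. The estimate for compound 3 in this assay is 128000 nM, with a range from 45000 nM to 400000 nM.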

Compound 3, half-maximal inhibitory concentration: > 128000 nM
Compound 3 ended at the assay's limit (the forecaster's own chance of this, stated with the estimate: 85%); the middle value lies on the limit itself.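

In this assay compound 3 gives > 128000 nM, a limit of the assay and not a number. The steps among compound 1, compound 2 and compound 3 therefore cannot be read. The compounds shown leave open at what concentration any of the three would inhibit, and whether their aromatic groups make any difference in this assay.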